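The compounds below may be only part of what the source reports. "The series", "measured", "known", "first", "only" and "open" are said of these compounds alone.

The three measured compounds share one core and differ only in the aryl group on an amide-type nitrogen. Compound 1 `COc1cc2cc(Oc3ccc(NC(=O)Nc4ccc(C)cc4)cc3)c(C)nc2cc1OC` gives 108% in a functional assay on NCI-H460 cells (Homo sapiens) for inhibition, read by sulforhodamine B assay, with a stated time of 48 h, tested at 10 uM; a higher number here means a weaker effect of the compound at the concentration tested, a lower number a stronger effect. Compound 2 `COc1cc2cc(Oc3ccc(NC(=O)Nc4ccc(C(F)(F)F)cc4)cc3)c(C)nc2cc1OC` gives 42.8% in this assay, and compound 3 `COc1cc2cc(Oc3ccc(NC(=O)Nc4cccc(C(F)(F)F)c4)cc3)c(C)nc2cc1OC` gives 2.68% in this assay. Compound 3 thus stands lowest of the three numbers, with compound 2 nearest and compound 1 furthest; both gaps are beyond the scatter, so compound 3 is the strongest of the three at the tested concentration. The measured steps show how much the aryl group matters: a number 65.2 percentage points lower from compound 1 to compound 2 (beyond the scatter), a number 105.3 percentage points lower from compound 1 to compound 3 (beyond the scatter), and a number 40.1 percentage points lower from compound 2 to compound 3 (beyond the scatter).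

Compound 4 `COc1cc2cc(Oc3ccc(NC(=O)Nc4ccc(Cl)c(Cl)c4)cc3)c(C)nc2cc1OC` has not yet been measured in this assay. Its difference from compound 3 is 3,4-dichlorophenyl in place of 3-(trifluoromethyl)phenyl on an amide-type nitrogen. Among the compounds with values here, none of the measured steps exchanges one aryl group for another of this kind, so they bear on the step only in showing that exchanges of the aryl group have moved the read-out by large amounts in this assay. Compound 3 already lies near the bottom of the scale, so the expected step from it is small or upward, estimated as a number 9.3 percentage points higher from compound 3 to compound 4 (within the scatter). Compound 4 is therefore expected to give about 12% in this assay, with an estimated range from 0% to 45%.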

Compound 4, a percentage reported as activity, at one concentration (the size of the read-out at that concentration, not a potency): 3.68%
Beside the measured number, compound 4's estimate is 8.3 percentage points above it; low and high end bracket the measured number.
By their numbers in this assay, from the lowest: compounds 3 and 4 (each within the scatter of the next); then compound 2; then compound 1.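

In this assay the exchange of 3-(trifluoromethyl)phenyl for 3,4-dichlorophenyl on the amide-type nitrogen gives a number 1 percentage points higher from compound 3 to compound 4 (within the scatter) and so shows that a low read-out at this place does not depend on trifluoromethyl: an aryl group carrying two chlorine atoms and no fluorine stands level with it. The other two steps, a number 39.1 percentage points lower from compound 2 to compound 4 (beyond the scatter) and a number 104.3 percentage points lower from compound 1 to compound 4 (beyond the scatter) in the same assay, separate compound 4 from the 4-(trifluoromethyl)phenyl and 4-methylphenyl compounds by large amounts, as compound 3 was already separated from them. Nothing available here accounts for the differences among these aryl groups.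

Each read-out gives the size of the effect at a single concentration, so the numbers leave open whether compound 3 and compound 4 would still stand level at lower concentrations. On these data alone, it also remains open how the read-out would respond to an aryl group bearing a single chlorine, a methoxy group, an amine or a carboxylic acid, or to a saturated ring such as cyclohexyl on the same nitrogen.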